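A few compounds are considered here, and "the series" means these few. Any claim that something is new, unique, unknown or untested is made for them only; others in the source may bear on it.

Compound 1 `O=c1oc(-c2ccccc2)nn1CCCCN1CCN(C2CCCCC2)CC1` and compound 2 `O=c1oc(-c2ccccc2)nn1CCCCN1CCN(c2ccc(F)cc2)CC1` share one core, while compound 3 `O=C1CCc2ccccc2N1CCCCN1CCN(C2CCCCC2)CC1` and the not yet measured compound 4 `O=C1CCc2ccccc2N1CCCCN1CCN(c2ccc(F)cc2)CC1` share another; the difference between the two cores is not broken down here. In an assay on membranes from liver for displacement of a labelled ligand from Sigma intracellular receptor 2 (Rattus norvegicus), read by scintillation counting, with a stated time of 120 min, in the presence of a further agent that is not named here (on this read-out lower numbers stand for stronger inhibition and higher numbers for weaker inhibition), compound 1 gives 93 nM, compound 2 gives 686 nM and compound 3 gives 1.5 nM. Between the first two the change is 4-fluorophenyl in place of cyclohexyl on an amine nitrogen in a ring, and it produced a 7.4-fold higher number from compound 1 to compound 2 (0.87 log units; beyond the scatter). Applying the same change, (4-fluorophenyl in place of cyclohexyl on an amine nitrogen in a ring), to compound 3 gives compound 4, for which the expected step is a 7.3-fold higher number from compound 3 to compound 4 (0.87 log units; beyond the scatter), because the only measured example of this change gave a 7.4-fold higher number from compound 1 to compound 2 (0.87 log units; beyond the scatter). Compound 4 is therefore estimated at 11 nM in this assay, with a likely range from 4 nM to 35 nM.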

Compound 4, inhibition constant: 21 nM
Estimate against measurement, compound 4: 1.9-fold (0.28 log units) below, and the stated range covers the measured number.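

In this assay, putting 4-fluorophenyl in place of cyclohexyl on the second core gave a 14-fold higher number from compound 3 to compound 4 (1.15 log units; beyond the scatter). The change therefore weakened inhibition on both cores, and the two steps agree in size as far as the scatter of the measurements can tell: the same change on two cores in this assay, a 7.4-fold higher number (0.87 log units; beyond the scatter) from compound 1 to compound 2 and a 14-fold higher number (1.15 log units; beyond the scatter) from compound 3 to compound 4, 1.9-fold (0.28 log units) apart, within the scatter of two such steps. Going by these compounds alone, this rests on only two pairs of compounds, so it does not show that the step would hold on a third core, nor does it explain why the change has this effect.

The compounds shown leave open whether another group on the amine nitrogen in the ring, such as plain phenyl or methyl, would behave the same way on both cores. They also leave open whether the step would stay the same with a longer chain.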